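Chloro for Fluoro on a Sulfonyl Aryl Ring

A few compounds are considered here, and "the series" means these few. Any claim that something is new, unique, unknown or untested is made for them only; others in the source may bear on it.

Compound 1 `O=C(C1CCC(F)(F)CC1)N1CC(c2nc(-c3cccc(F)c3)no2)C1` and compound 3 `O=C(C1CCC(F)(F)CC1)N1CC(c2nc(-c3cccc(Cl)c3)no2)C1` share one core; compound 2 `O=S(=O)(c1ccc(F)cc1)N1CC(c2nc(-c3cccc(Cl)c3)no2)C1` and the not yet measured compound 4 `O=S(=O)(c1ccc(Cl)cc1)N1CC(c2nc(-c3cccc(Cl)c3)no2)C1` share another. The difference between the two cores is not broken down here. In an assay on HEK293 cells for negative allosteric modulation of metabotropic glutamate receptor 5 (Homo sapiens), read by FLIPR (a lower number here means a stronger inhibitor, a higher number a weaker inhibitor), compound 1 gives a limit of the assay, > 10000 nM. Compound 3 likewise gives a limit, > 10000 nM. Compound 2 gives a number, 130 nM.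

Compound 1 becomes compound 3 by chloro in place of fluoro on an aromatic carbon, and the result is a step that the two limits leave unreadable from compound 1 to compound 3 because of the limit of > 10000 nM in this assay, at which 2 of the 3 values shown sit. Compound 2 becomes compound 4 by chloro in place of fluoro on an aromatic carbon. This is the same kind of change, but the place differs: meta to a large group in the first pair, para to a large group in the second. Among the compounds with values here, the one measured instance of this change gives no readable size, and the expectation rests on compound 2 alone, whose value 130 nM is the anchor, with a small step assumed. From compound 2 to compound 4 a step of a 1.3-fold lower number from compound 2 to compound 4 (0.11 log units; within the scatter) is expected in this assay. Compound 4 is estimated at 100 nM, between 40 nM and 300 nM.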

Compound 4, half-maximal inhibitory concentration: 170 nM
Compound 4: middle estimate off by 1.7-fold (0.23 log units), on the low side, and the stated range covers the measured number.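

In this assay, chloro in place of fluoro gives a 1.3-fold higher number from compound 2 to compound 4 (0.12 log units; within the scatter), so in the core of compound 2 the 4-fluorophenyl and 4-chlorophenyl forms cannot be told apart. In the core of compound 1 the same kind of change cannot be read, because compound 1 and compound 3 each give only a limit of the assay: the limit of > 10000 nM in this assay, at which 2 of the 4 values shown sit. This leaves one readable pair, which shows that the swap is tolerated at this one place in this one core, but it does not show that the change carries from one core to another, particularly as the place on the ring also differs between the two pairs.

As far as these compounds go, it remains open whether a group unlike these two halogens, such as a nitrile, a methoxy group or an amine, would leave the number equally undisturbed in place of the chloro para to a large group. Also open, from the compounds shown here alone, is how the same swap would read on the other aromatic ring of compound 2.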